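Working notes: aryl swap on the ring nitrogen, compound 4

The compounds below may be only part of what the source reports. "The series", "measured", "known", "first", "only" and "open" are said of these compounds alone.

The series shares one core, seen in compound 1 `O=C(CSc1nc(Nc2ccccc2)c2ccccc2n1)Nc1ccc(C(F)(F)F)cc1` and compound 2 `O=C(CSc1nc(Nc2ccccc2)c2ccccc2n1)Nc1ccc(Cl)cc1Cl`. In a functional assay on MDA-MB-231 cells (Homo sapiens) for inhibition, read by MTT assay, with a stated time of 72 h (a higher number here means a weaker inhibitor, a lower number a stronger inhibitor), compound 1 gives 11100 nM and compound 2 gives 19400 nM. Among the measured compounds shown here, the only single-point step among the measured compounds is a 1.7-fold higher number from compound 1 to compound 2 (0.24 log units; within the scatter). For the measured compounds named here, compound 3 `C=CC(=O)Nc1cccc(NC(=O)CSc2nc(Nc3ccccc3Cl)c3ccccc3n2)c1` differs from both of these at more than one place, so no single step connects it to them; in this assay compound 3 gives 12700 nM. Its number sits between those of compound 1 and compound 2, and its gap to each is within the scatter, so the three measured compounds are not separated from one another on this read-out.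

Compound 4 `C=CC(=O)Nc1cccc(NC(=O)CSc2nc(Nc3cccc(F)c3)c3ccccc3n2)c1` is not yet measured. The change from compound 3 is 3-fluorophenyl in place of 2-chlorophenyl on a nitrogen on an aromatic ring. Going by the values given here, no measured step touches this nitrogen: the one step available sits on the amide-type nitrogen, and that step itself stayed within the scatter. Nothing in the measured numbers therefore points to a step beyond the scatter in this assay, in either direction. The expected step is a 1.1-fold lower number from compound 3 to compound 4 (0.02 log units; within the scatter). Compound 4 is expected to give about 12000 nM, with a range from 5000 nM to 30000 nM.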

Compound 4, half-maximal inhibitory concentration: 8160 nM
For compound 4 the middle estimate is 1.5-fold (0.17 log units) above the measured one; the range from low to high includes it.
By their numbers in this assay, from the lowest: compounds 4, 1, 3 and 2 (each within the scatter of the next, the first and the last beyond it).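

The nitrogen on an aromatic ring now has its first measured step: in this assay, the exchange of 2-chlorophenyl for 3-fluorophenyl gives a 1.6-fold lower number from compound 3 to compound 4 (0.19 log units; within the scatter). The earlier compounds shown here offered a single-point step only on the amide-type nitrogen, a 1.7-fold higher number from compound 1 to compound 2 (0.24 log units; within the scatter), so both places with a readable step now show a change within the scatter, and this aryl exchange does not separate compound 3 from compound 4 on this read-out. The data offered here include nothing that bears on the origin of this step.

Because this single step alters both the halogen and the name-position of the aryl substituent, the two changes cannot be told apart, and a 3-chlorophenyl or 2-fluorophenyl group on this nitrogen would be needed to divide them. Going by these compounds, it also remains open whether a group of a different kind at this place, such as a phenyl ring carrying an amine or a carboxylic acid, or a longer alkyl chain in place of the aryl ring, would give a step beyond the scatter in this assay.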